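The source may report more compounds than this note shows. Statements on the series, on what has been measured and on what is new or still open speak of the compounds shown alone.

Measured so far, in a functional assay (plasma) for inhibition, with Oryctolagus cuniculus as the target; a lower number here means a stronger inhibitor, a higher number a weaker inhibitor:

Compound 1, `CC1(C)[C@H]2C[C@H](NC(=O)[C@H](O)C3CCCC3)[C@@H](C/C=C\CCCC(=O)O)[C@@H]1C2`: in this assay compound 1 gives only a limit, > 800000 nM, not a number.
Compound 2, `Cc1ccc(S(=O)(=O)N[C@H]2C3CC[C@H](C3)[C@@H]2C/C=C\CCCC(=O)O)cc1`: in this assay compound 2 gives 500 nM.
Compound 3, `O=C(O)CCC/C=C\C[C@H]1[C@@H]2CCC(C2)[C@@H]1NS(=O)(=O)c1ccc(F)cc1`: in this assay compound 3 gives 600 nM.

Among the compounds with values here, compound 2 holds the lowest of the two real numbers here, yet its nearest neighbour, compound 3, sits so close that the two cannot be told apart: the only measured step between a directly comparable pair, a 1.2-fold higher number from compound 2 to compound 3 (0.08 log units; within the scatter), stays inside the scatter of the assay. Within the data shown here, compound 1, whose value is a limit, (the limit of > 800000 nM in this assay, at which 1 of the 3 values shown sits), offers no measured step to any other compound and so gives no guidance on substituent changes.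

The compound still to be measured is compound 4, `CN(C)c1ccc(S(=O)(=O)N[C@H]2C3CC[C@H](C3)[C@@H]2C/C=C\CCCC(=O)O)cc1`. It differs from compound 2 in one place: dimethylamino in place of methyl on an aromatic carbon. Among the measured compounds shown here, the one measured step that bears on this, the swap of fluoro for methyl on the same aromatic carbon between compound 2 and compound 3, left the number essentially unchanged. On that basis the expectation for compound 4 is a step no larger than the scatter, a 1.2-fold higher number from compound 2 to compound 4 (0.08 log units; within the scatter), with no clear direction. Compound 4 is therefore estimated at 600 nM, in a range from 200 nM to 2000 nM.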

Compound 4, half-maximal inhibitory concentration: 7100 nM
For compound 4 the middle estimate is 12-fold (1.07 log units) below the measured one, outside the stated range (above it).
By their numbers in this assay, from the lowest: compounds 2 and 3 (each within the scatter of the next); then compound 4. At a limit, above all of these: compound 1.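

Read in this assay, the aromatic carbon para to a large group proves sensitive to its substituent: methyl and fluoro could not be told apart there, whereas dimethylamino gives a clearly higher number, meaning a weaker inhibitor, from either starting point (a 14-fold higher number from compound 2 to compound 4 (1.15 log units; beyond the scatter) and a 12-fold higher number from compound 3 to compound 4 (1.07 log units; beyond the scatter)). Within the data shown here, the near-identical values of compound 2 and compound 3 therefore described only that pair and did not carry over to every group at this place. Among the compounds shown, dimethylamino, with 3 heavy atoms and 1 hydrogen-bond acceptor against the 1 heavy atom and no acceptor of methyl, is the only group on this ring that moves the number beyond the scatter, and no measurement shown here bears on the reason for that rise.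

From the compounds shown here alone, it remains open whether the nitrogen or the two added carbons matter more, a question that a plain amine or a methoxy group at the same place could help to separate. A single result also cannot show whether a longer chain, such as ethyl, would raise the number in the same way.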